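The source may hold more compounds than are shown below. What is called first, only, known or untested is meant among the compounds shown, and "the series" means these compounds.

In an assay on HEK293 cells for displacement of a labelled ligand from Melanocortin receptor 4 (Homo sapiens) (on this read-out higher numbers stand for weaker inhibition and lower numbers for stronger inhibition), compound 3 `CC(C)C[C@H](N)c1cc(C(F)(F)F)ccc1N1CCN(C(=O)COc2ccc(Cl)cc2)CC1` gives 2900 nM, the highest number among the three measured compounds, though a 1.5-fold higher number from compound 1 to compound 3 (0.16 log units; within the scatter) lies within the scatter. Compound 1 `CC(C)C[C@H](N)c1cc(C(F)(F)F)ccc1N1CCN(C(=O)COc2ccc3ccccc3c2)CC1` gives 2000 nM and compound 2 `CC(C)C[C@H](N)c1cc(C(F)(F)F)ccc1N1CCN(C(=O)CCC(=O)c2ccc(Cl)cc2)CC1` gives 820 nM in this assay. Compound 4 `CCOc1cccc(CC(C)C(=O)N2CCN(c3ccc(C(F)(F)F)cc3[C@@H](N)CC(C)C)CC2)c1` differs from compound 3 in one place: 1-(3-ethoxybenzyl)ethyl in place of (4-chlorophenoxy)methyl on a carbonyl carbon. The step that bears most on it is a 3.5-fold higher number from compound 2 to compound 3 (0.55 log units; beyond the scatter), a modest change that compound 4 may partly reverse since it also carries a carbon chain on the carbonyl carbon; a 2.4-fold lower number from compound 1 to compound 2 (0.39 log units; beyond the scatter) points the same way. Compound 4 is therefore expected to show a modest move, a 1.9-fold lower number from compound 3 to compound 4 (0.29 log units; within the scatter), giving an estimated 1500 nM with a range from 600 nM to 4000 nM in this assay.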

Compound 4, inhibition constant: 2200 nM
Estimate against measurement, compound 4: 1.5-fold (0.17 log units) below; measured number inside the range.
By their numbers in this assay, from the lowest: compound 2; then compounds 1, 4 and 3 (each within the scatter of the next).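

In this assay, 1-(3-ethoxybenzyl)ethyl on the carbonyl carbon gives a 1.3-fold lower number from compound 3 to compound 4 (0.12 log units; within the scatter) against (4-chlorophenoxy)methyl and a 1.1-fold higher number from compound 1 to compound 4 (0.04 log units; within the scatter) against ((naphthalen-2-yl)oxy)methyl, so neither replacement moves the number beyond the scatter. A carbon chain at this position therefore does not by itself restore the lower number, since 2-((4-chlorophenyl)carbonyl)ethyl stays apart, with a 2.7-fold higher number from compound 2 to compound 4 (0.43 log units; beyond the scatter). Nothing available explains these steps. Going by these compounds, whether an amine, a carboxylic acid or a longer chain carrying the carbonyl of compound 2 would take the number lower at this position stays open.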